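What to expect when a methyl gives way to hydrogen

The source may hold more compounds than are shown below. What is called first, only, known or untested is meant among the compounds shown, and "the series" means these compounds.

Values so far in a functional assay on DU-145 cells (Homo sapiens) for cytotoxicity, read by MTT assay, with a stated time of 48 h; on this read-out lower numbers stand for stronger inhibition and higher numbers for weaker inhibition
Compound 1 `COc1ccc2c(c1)C(C)=CC(C)(C)N2Cc1cn(Cc2cc3cc(OC)ccc3nc2Cl)nn1` gives 28600 nM
Compound 2 `CC1=CC(C)(C)N(Cc2cn(Cc3cc4cc(C)ccc4nc3Cl)nn2)c2ccccc21` gives 31300 nM
Compound 3 `COc1ccc2nc(Cl)c(Cn3cc(CN4c5ccccc5C(C)=CC4(C)C)nn3)cc2c1` gives 34000 nM

Compound 2 cannot be ranked against the other two, since its value lies within the usual scatter of both. For now, the three compounds read as a single level in this assay and show no real separation.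

Compound 4 `CC1=CC(C)(C)N(Cc2cn(Cc3cc4ccccc4nc3Cl)nn2)c2ccccc21` has not been measured yet. For the measured compounds named here, its one change from compound 2 is hydrogen in place of methyl on an aromatic carbon, in detail hydrogen in place of methyl on an aromatic carbon and nothing else.

Going by the values given here, two measured steps bear on this change. Replacing that same methyl with methoxy gave a 1.1-fold higher number from compound 2 to compound 3 (0.04 log units; within the scatter) and so moved the number no further than repeat measurements would. Putting hydrogen in place of methoxy on an aromatic carbon, at another place in the molecule, gave a 1.2-fold higher number from compound 1 to compound 3 (0.08 log units; within the scatter) and stayed within the scatter too. Neither step tests hydrogen for methyl directly, but both are small, so no step beyond the scatter is expected here. The expected step is a 1.0-fold lower number from compound 2 to compound 4 (0.02 log units; within the scatter) and it should stay within the scatter. Compound 4 is estimated at 30000 nM with a range of 17000 nM to 55000 nM in repeat measurements.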

Compound 4, half-maximal inhibitory concentration: 19300 nM
Compound 4: the middle estimate sits 1.6-fold (0.19 log units) above what was measured; the measured number falls inside the stated range.
By their numbers in this assay, from the lowest: compounds 4, 1, 2 and 3 (each within the scatter of the next).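

In this assay, one aromatic carbon, on the six-membered ring of carbon only, now carries three different groups across the series: methyl in compound 2, methoxy in compound 3 and plain hydrogen in compound 4. Until now this carbon had only seen one substituent traded for another, whereas here the group is removed altogether: taking away the methyl gives a 1.6-fold lower number from compound 2 to compound 4 (0.21 log units; within the scatter) and taking away the methoxy gives a 1.8-fold lower number from compound 3 to compound 4 (0.25 log units; within the scatter) while the rest of the molecule stays the same. Both steps are the largest seen so far in this short series, yet both stay within the scatter, so having no substituent at all on this carbon reads at the same level as having either small group there. Still open, going by these compounds, is whether a larger or very different group on this carbon, such as a carboxylic acid, an amine or a longer chain like butyl, would move the number beyond the scatter, and whether any change here could bring these compounds out of their present level. Nothing else measured on these compounds helps to explain the numbers seen here.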